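The source may report more compounds than this note shows. Statements on the series, on what has been measured and on what is new or still open speak of the compounds shown alone.

Compound 3 `CCCSc1nsnc1[C@H]1CN2CCC[C@@H]1C2` gives the lowest number of the three compounds in a functional assay on the whole organism for inhibition, with Rattus norvegicus as the target (on this read-out higher numbers stand for an effect only at larger amounts of compound and lower numbers for an effect already at smaller amounts), at 0.013 mg/kg. Compound 1 `CCCCSc1nsnc1[C@@H]1CN2CCC[C@H]1C2` gives 0.018 mg/kg in this assay, and compound 2 `CCCSc1nsnc1C1CN2CCC[C@H]1C2` gives 0.056 mg/kg. The step of a 4.3-fold lower number from compound 2 to compound 3 (0.63 log units; beyond the scatter) rests on (the fact that one of compounds 2 and 3 is drawn with a defined configuration and the other without, at the place where they differ). Compound 4 `CCCSc1nsnc1[C@@H]1CN2CCC[C@H]1C2` differs from compound 3 by the two compounds have the same atoms and bonds; at least one stereo element is drawn with a configuration in one of them and without one in the other: 2 of 3 stereo elements differ; a stereocentre at a saturated ring carbon is drawn R in compound 3 and S in compound 4; a stereocentre at a saturated ring carbon is drawn S in compound 3 and R in compound 4, so the two compounds share atoms and bonds and differ only in the drawn configuration at both ring stereocentres. For the measured compounds named here, the only measured step that touches configuration is a 4.3-fold lower number from compound 2 to compound 3 (0.63 log units; beyond the scatter), which is modest but beyond the scatter. Inverting both centres is therefore expected to raise the number, by a modest step of a 3.1-fold higher number from compound 3 to compound 4 (0.49 log units; beyond the scatter) in this assay. Compound 4 is estimated at 0.04 mg/kg in this assay, with a range from 0.012 mg/kg to 0.15 mg/kg.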

Compound 4, dose for half-maximal effect: 0.03 mg/kg
The estimate for compound 4 lay 1.3-fold (0.12 log units) above the measured number; measured number inside the range.
By their numbers in this assay, from the lowest: compounds 3, 1, 4 and 2 (each within the scatter of the next, the first and the last beyond it).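

Inverting both ring stereocentres, with atoms and bonds unchanged, gives a 2.3-fold higher number from compound 3 to compound 4 (0.36 log units; beyond the scatter) in this assay, so drawn configuration alone separates these two compounds. By contrast, drawing the open stereocentre as S gives a 1.9-fold lower number from compound 2 to compound 4 (0.27 log units; within the scatter), and hydrogen in place of methyl on a saturated chain carbon, three bonds along the chain from a sulfur, gives a 1.7-fold higher number from compound 1 to compound 4 (0.22 log units; within the scatter); both steps stay within the scatter. For the compounds shown here, the chain change is therefore seen only in the configuration of compound 4. From the compounds shown here alone, how a longer chain, such as pentyl, or an amine in place of the sulfur chain would read in the configuration of compound 3 remains open.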